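Trading Isobutyl for Trifluoromethyl

The source may report more compounds than this note shows. Statements on the series, on what has been measured and on what is new or still open speak of the compounds shown alone.

In a functional assay on KBVIN cells (Homo sapiens) for antiproliferative activity, read by sulforhodamine B assay, with a stated time of 3 days (on this read-out higher numbers stand for an effect only at larger amounts of compound and lower numbers for an effect already at smaller amounts), compound 1 `CCC1=C(O)c2c(oc(-c3ccc(CC)cc3)cc2=O)C(CC)(CC)C1=O` gives 0.07 uM, while compound 2 `CCC1=C(O)c2c(oc(-c3ccc(CC(C)C)cc3)cc2=O)C(CC)(CC)C1=O` gives 17.4 uM. Compound 2 therefore holds the higher of the two numbers. Compound 3 `CCC1=C(O)c2c(oc(-c3ccc(C(F)(F)F)cc3)cc2=O)C(CC)(CC)C1=O` has not yet been measured, and its difference from compound 2 is trifluoromethyl in place of isobutyl on an aromatic carbon.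

Within the data shown here, only one measured step bears on this change. It is a 250-fold higher number from compound 1 to compound 2 (2.40 log units; beyond the scatter), a large step that comes from isopropyl in place of methyl on a saturated chain carbon. Both measured compounds carry saturated chains at this place, and neither carries fluorine, so this step suggests a direction but does not fix a size. With the isobutyl group gone, a clear fall in the number is expected, though not necessarily all the way to compound 1 at 0.07 uM. The expected step is a 17-fold lower number from compound 2 to compound 3 (1.24 log units; beyond the scatter), well beyond the scatter. For compound 3 the estimated value is 1 uM, with an expected range from 0.1 uM to 10 uM.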

Compound 3, concentration for half-maximal effect: 10.4 uM
Compound 3: the middle estimate sits 10-fold (1.02 log units) below what was measured; measured number outside the range, above it.
By their numbers in this assay, from the lowest: compound 1; then compounds 3 and 2 (each within the scatter of the next).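

In this assay, trifluoromethyl and isobutyl cannot be told apart at this place on the aromatic ring (compound 2 to compound 3 reads as a 1.7-fold lower number from compound 2 to compound 3 (0.22 log units; within the scatter)), even though the two groups share no atom type beyond carbon and have the same count of heavy atoms. Set against the ethyl group, trifluoromethyl gives a second large step (a 150-fold higher number from compound 1 to compound 3 (2.17 log units; beyond the scatter)), so the large step is no longer tied to the branched saturated chain of compound 2 and also appears with a group that has no chain at all. Among these three compounds, ethyl alone goes with the low number, but nothing measured here accounts for that or for the close agreement of the other two groups.

The compounds shown leave open whether the low number belongs to ethyl alone or extends to a methyl group, an unbranched propyl chain or a longer chain at this place. They also leave open how a methoxy group or an amine, which would place a different atom on the aromatic carbon, would read here.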